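The compounds below may be only part of what the source reports. "The series", "measured", "known", "first", "only" and "open" are said of these compounds alone.

Compound 1 `CC1=NC(C)=C(C(=O)O)C(c2ccccc2)/C1=C(\O)OC/C=C/c1ccccc1`: 9 nM in a functional assay on thoracic aorta for inhibition of Voltage-gated L-type calcium channel (Rattus norvegicus); on this read-out higher numbers stand for weaker inhibition and lower numbers for stronger inhibition.
Compound 2 `CC1=NC(C)=C(C(=O)O)C(c2cccc(I)c2)/C1=C(\O)OC/C=C/c1ccccc1`: 13 nM in this assay.

Compound 2 holds the higher of the two numbers, but the step of a 1.4-fold higher number from compound 1 to compound 2 (0.16 log units; within the scatter) lies within the scatter, so the two compounds cannot be ordered against each other. Compound 3 `CC1=NC(C)=C(C(=O)O)C(c2cccnc2)/C1=C(\O)OC/C=C/c1ccccc1` is not yet measured. It differs from compound 2 by pyridin-3-yl in place of 3-iodophenyl on a saturated ring carbon. Going by the values given here, the only measured step, a 1.4-fold higher number from compound 1 to compound 2 (0.16 log units; within the scatter), exchanges a hydrogen for iodo on an aromatic carbon and bears only loosely on the present change; no measured pair exchanges an aromatic carbon ring for a ring with a nitrogen, so that exchange is untested here. With nothing in the series pointing to a large shift, compound 3 is estimated at 25 nM (range 8 nM to 80 nM). The expected step is a 1.9-fold higher number from compound 2 to compound 3 (0.28 log units; within the scatter), which need not exceed the scatter.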

Compound 3, half-maximal inhibitory concentration: 190 nM
Compound 3: middle estimate off by 7.6-fold (0.88 log units), on the low side; measured number outside the range, above it.
By their numbers in this assay, from the lowest: compounds 1 and 2 (each within the scatter of the next); then compound 3.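

Unlike the iodo exchange on an aromatic carbon, the change of the whole ring on the saturated ring carbon is not tolerated without cost in this assay: pyridin-3-yl in place of 3-iodophenyl gives (a 15-fold higher number from compound 2 to compound 3 (1.16 log units; beyond the scatter)), and pyridin-3-yl in place of phenyl gives (a 21-fold higher number from compound 1 to compound 3 (1.32 log units; beyond the scatter)). The second step is the cleaner reading, since the entering and leaving rings differ only in a ring nitrogen, so at this position that single exchange is enough for a large step. The series holds no measurement that bears on why the number rises.

From the compounds shown here alone, whether the step belongs to a ring nitrogen at this particular ring place remains open, as pyridin-2-yl and pyridin-4-yl would test that. Also open, going by these compounds, is whether an amine or a methoxy group on the phenyl ring would give a comparable step.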